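Moving a chlorine on the cinnamamide of compound 2

This account rests on a few compounds, and the source may have more. Where it says the series, first, only, none or still open, it means among the compounds named here.

Compound 1, `CCCc1cc(N)c2cc(NC(=O)/C=C/c3ccc(C(C)C)cc3)ccc2n1`: 2.9 nM
Compound 2, `CCCc1cc(N)c2cc(NC(=O)/C=C/c3ccc(Cl)c(Cl)c3)ccc2n1`: 60 nM

In an assay on isolated protein for displacement of a labelled ligand from melanin-concentrating hormone receptor 1 (Homo sapiens) (on this read-out lower numbers stand for stronger inhibition and higher numbers for weaker inhibition), compound 2 gives the highest of the two numbers on record; its nearest neighbour, compound 1, lies lower, and that gap, a 21-fold higher number from compound 1 to compound 2 (1.32 log units; beyond the scatter), is beyond the scatter. Compound 3, `CCCc1cc(N)c2cc(NC(=O)/C=C/c3ccc(Cl)cc3Cl)ccc2n1`, is not yet measured. It differs from compound 2 only in the arrangement of the same atoms: 2,4-dichlorophenyl in place of 3,4-dichlorophenyl on a double-bonded chain carbon bound to a double-bonded chain carbon. Going by the values given here, the one measured step, from compound 1 to compound 2, exchanged a whole substituent pattern and was large; it does not show what moving a chlorine within the dichlorophenyl does, so no measured step bears directly on this change. With nothing in the data to point in either direction, compound 3 is expected to stay close to compound 2, a step of no change at the digits printed from compound 2 to compound 3 (within the scatter) in this assay, not beyond the scatter. Compound 3 is therefore estimated at 60 nM in this assay, with a range from 15 nM to 250 nM.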

Compound 3, half-maximal inhibitory concentration: 6.6 nM
Compound 3: the middle estimate sits 9.1-fold (0.96 log units) above what was measured; measured number below the stated range.
By their numbers in this assay, from the lowest: compound 1; then compound 3; then compound 2.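

In this assay the arrangement of the chlorines on the phenyl ring matters in its own right: with the same atoms attached at the same chain carbon, the change to 2,4-dichlorophenyl gives a 9.1-fold lower number from compound 2 to compound 3 (0.96 log units; beyond the scatter) and recovers much of the ground lost earlier. The large gap first seen on leaving 4-isopropylphenyl, a 21-fold higher number from compound 1 to compound 2 (1.32 log units; beyond the scatter) in this assay, therefore cannot be read as a general penalty for a dichlorophenyl group, since the other dichloro pattern gives only a 2.3-fold higher number from compound 1 to compound 3 (0.36 log units; beyond the scatter) and leaves compound 1 with the lowest number of the three by a much narrower margin. No measurement offered here says why the arrangement of the chlorines has this effect.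

The compounds shown leave open whether compound 3 owes its number to both chlorines, or whether a single chlorine, a fluorine or a methoxy group on the phenyl ring would do as well. They also leave open whether 2,4-dichlorophenyl would keep its lead over 3,4-dichlorophenyl with a longer chain in place of the propyl group on the shared core.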